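The source may report more compounds than this note shows. Statements on the series, on what has been measured and on what is new or still open speak of the compounds shown alone.

Measured compounds in an assay on isolated protein with Bile acid receptor (Homo sapiens) as the target; on this read-out higher numbers stand for an effect only at larger amounts of compound and lower numbers for an effect already at smaller amounts: compound 1 `COC(=O)/C=C/c1cccc(N(Cc2ccc(/C=C/c3cc(C(F)(F)F)cc(C(F)(F)F)c3)cc2)C(=O)C(C)C)c1` gives 1950 nM; compound 2 `COC(=O)/C=C/c1cccc(N(Cc2ccc(/C=C/c3ccccn3)cc2)C(=O)C2CCCCC2)c1` gives 309 nM; compound 3 `COC(=O)/C=C/c1cccc(N(Cc2ccc(/C=C/c3ccccn3)cc2)C(=O)C(C)C)c1` gives 310 nM.

Compound 2 stands at the lowest number of the three in this assay, with compound 3 within the scatter of it and compound 1 well beyond it at the higher end. Among the compounds with values here, the only single-place step among the measured compounds is a 1.0-fold higher number from compound 2 to compound 3 (0.00 log units; within the scatter), which concerns the acyl group and not the aryl end of the molecule.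

Compound 4 `COC(=O)/C=C/c1cccc(N(Cc2ccc(-c3cccc(C)c3)cc2)C(=O)C2CCCCC2)c1` differs from compound 2 by 3-methylphenyl in place of 2-(pyridin-2-yl)ethenyl on an aromatic carbon. Within the data shown here, no measured step bears directly on this change. Compound 1 carries a different aryl group at that end and also a different acyl group, and its number is higher than that of compound 2; what compound 1 and compound 2 show is that changes at the aryl end can move the number well beyond the scatter, while the acyl change in compound 2 to compound 3 did not.

Compound 4 is therefore expected to give a higher number than compound 2, with the step of a 2.6-fold higher number from compound 2 to compound 4 (0.41 log units; beyond the scatter) as the estimate. For compound 4 the expected value in this assay is 800 nM, within a range from 250 nM to 2500 nM.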

Compound 4, half-maximal effective concentration: 109 nM
Compound 4: the middle estimate sits 7.3-fold (0.87 log units) above what was measured; measured number outside the range, below it.
By their numbers in this assay, from the lowest: compound 4; then compounds 2 and 3 (each within the scatter of the next); then compound 1.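

Within the data shown here, replacing 2-(pyridin-2-yl)ethenyl with 3-methylphenyl on the aromatic carbon para to a large group gives, in this assay, a 2.8-fold lower number from compound 2 to compound 4 (0.45 log units; beyond the scatter) and is the first single-place step at this end of the series. At this position, neither the double bond outside aromatic rings nor the ring nitrogen is needed for a number at the level of compound 4. No measured property accounts for this step.

From the compounds shown here alone, the step removes the double bond and the ring nitrogen together, so their separate contributions remain open. Also open, going by these compounds, is whether a methoxy group, a chlorine atom or an aminomethyl group could take the place of the methyl on the phenyl ring, and whether isopropyl could replace cyclohexyl on the carbonyl carbon of compound 4 with as little change as seen in a 1.0-fold higher number from compound 2 to compound 3 (0.00 log units; within the scatter) for the pyridine-bearing pair.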